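The source may hold more compounds than are shown below. What is called first, only, known or untested is meant among the compounds shown, and "the series" means these compounds.

Working notes on the series. In a functional assay on PC-3 cells (Homo sapiens) for inhibition, read by MTT assay, with a stated time of 48 h, tested at 10 uM (a higher number here means more inhibition of growth at the concentration tested, a lower number less inhibition of growth), compound 1 (`Cc1cc(=O)c2c(O)c(CN3CCCC3)c(O)c([C@H]3CCN(C)C[C@H]3O)c2o1`) gives 10%, compound 2 (`Cc1oc2c([C@H]3CCN(C)C[C@H]3O)c(O)cc(O)c2c(=O)c1C(O)c1ccc(Cl)cc1`) gives 41% and compound 3 (`Cc1oc2c([C@H]3CCN(C)C[C@H]3O)c(O)cc(O)c2c(=O)c1C(O)c1ccc(F)c(Br)c1`) gives 72%. Compound 3 is the highest of the three, beyond the scatter of both others.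

Next is compound 4 (`Cc1oc2c([C@H]3CCN(C)C[C@H]3O)c(O)cc(O)c2c(=O)c1C(O)c1cc(F)cc(F)c1`), with 3,5-difluorophenyl in place of 3-bromo-4-fluorophenyl on a saturated chain carbon bound to an aromatic carbon and an oxygen on a saturated carbon.

Among the measured compounds shown here, one measured step bears on this change: a number 31 percentage points higher from compound 2 to compound 3 (beyond the scatter), a large step beyond the scatter, with 3-bromo-4-fluorophenyl in place of 4-chlorophenyl. For the measured compounds named here, compound 1 offers no single-place step here. Going by the values given here, that one step shows that this assay can respond strongly to a swap of this group, but no measured compound carries 3,5-difluorophenyl, so the direction remains uncertain.

A moderate fall is expected, with a number 17 percentage points lower from compound 3 to compound 4 (beyond the scatter) as the estimated step. For compound 4 the estimated value is 55%, with an expected range of 33% to 76%.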

Compound 4, percent growth inhibition at one concentration: 0%
For compound 4 the middle estimate is 55 percentage points above the measured one; the whole stated range lies above it.
By their numbers in this assay, from the lowest: compounds 4 and 1 (each within the scatter of the next); then compound 2; then compound 3.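

In this assay the aryl group on a saturated chain carbon bound to an aromatic carbon and an oxygen on a saturated carbon can take the number down as well as up: 3,5-difluorophenyl falls short of 3-bromo-4-fluorophenyl (a number 72 percentage points lower from compound 3 to compound 4 (beyond the scatter)) and of 4-chlorophenyl (a number 41 percentage points lower from compound 2 to compound 4 (beyond the scatter)). The two groups in the first step have the same count of heavy atoms and the same aromatic ring, so that count does not separate them, and a halogen on the phenyl ring does not by itself keep the growth inhibition seen with compound 2 and compound 3. Nothing available bears on why this change lowers the number.

The compounds shown leave open whether the loss follows from the absence of bromine or from the changed halogen pattern, as compound 3 and compound 4 differ in both. Also open, going by these compounds, is how an unsubstituted phenyl, or a phenyl carrying an amine or a carboxylic acid, would read at this position.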